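Bromo to ethyl on the shared core: compound 4

A few compounds are considered here, and "the series" means these few. Any claim that something is new, unique, unknown or untested is made for them only; others in the source may bear on it.

Three ureas on the same core have been measured in a functional assay on HEK293 cells for antagonist activity at transient receptor potential cation channel subfamily V member 1 (Rattus norvegicus); on this read-out higher numbers stand for weaker inhibition and lower numbers for stronger inhibition. Compound 1 `Cc1ccc(NC(=O)N2CCN(c3ncccc3C(F)(F)F)CC2)cc1` gives 1550 nM. Compound 2 `CC(C)c1ccc(NC(=O)N2CCN(c3ncccc3Cl)CC2)cc1` gives 17.3 nM, and compound 3 `CC(C)c1ccc(NC(=O)N2CCN(c3ncccc3Br)CC2)cc1` gives 27.1 nM. Compound 3 thus stands second of the three numbers; its nearest neighbour is compound 2, and the change a 1.6-fold higher number from compound 2 to compound 3 (0.19 log units; within the scatter) is within the scatter, so no order between compound 2 and compound 3 can be read. Compound 1 lies far weaker than compound 3 in this assay, but it differs from compound 3 in two places, so that gap cannot be tied to any single change.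

Compound 4 `CCc1cccnc1N1CCN(C(=O)Nc2ccc(C(C)C)cc2)CC1` is not yet measured. The change from compound 3 reads (ethyl in place of bromo on an aromatic carbon). Within the data shown here, no measured pair carries this change. Among the measured compounds shown here, the only single-place step recorded, a 1.6-fold higher number from compound 2 to compound 3 (0.19 log units; within the scatter), exchanges chloro for bromo and leaves the number within the scatter; it is the sole guide and does not involve ethyl. The step is therefore expected to be a 1.3-fold higher number from compound 3 to compound 4 (0.11 log units; within the scatter), with wide bounds for the untested group. Compound 4 is estimated at 35 nM in this assay, with a range from 12 nM to 110 nM.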

Compound 4, half-maximal inhibitory concentration: 828 nM
The estimate for compound 4 lay 24-fold (1.37 log units) below the measured number, outside the stated range (above it).
By their numbers in this assay, from the lowest: compounds 2 and 3 (each within the scatter of the next); then compounds 4 and 1 (each within the scatter of the next).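

In this assay, ethyl in place of bromo gives a 31-fold higher number from compound 3 to compound 4 (1.49 log units; beyond the scatter) and is large, and ethyl in place of chloro gives a 48-fold higher number from compound 2 to compound 4 (1.68 log units; beyond the scatter) and is also large. Among these compounds, the only earlier step at this position, a 1.6-fold higher number from compound 2 to compound 3 (0.19 log units; within the scatter) for bromo in place of chloro, showed no change that could be read, so the new result is the first sign that this aromatic carbon, two atoms from the ring nitrogen, responds to the group it carries: the number stays level between the two halogens but not on going to ethyl, even though the exchange only takes 1 heavy atom to 2 heavy atoms and neither group has a hydrogen-bond donor or acceptor. No measurement at hand accounts for the size of this step.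

Going by these compounds, whether methyl would stay with chloro and bromo or fall with ethyl remains open, as does the outcome for methoxy or a nitrile at this position. Compound 1 carries trifluoromethyl here but differs from compound 3 in two places, so the effect of that group on this core also remains unresolved.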